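Swapping chloro for fluoro on compound 3's pendant phenyl

The compounds below may be only part of what the source reports. "The series", "measured", "known", "first", "only" and "open" are said of these compounds alone.

Of the compounds shown here, three have been measured in a functional assay on A549 cells (Homo sapiens) for cytotoxicity, read by MTT assay, with a stated time of 72 h; a lower number here means a stronger inhibitor, a higher number a weaker inhibitor. Compound 1 `Fc1ccc(Nc2cc(Nc3ccc(Oc4ccncc4-c4cccnc4)c(F)c3)ncn2)cc1F` gives 7630 nM, and compound 2 `Fc1ccc(Nc2cc(Nc3ccc(Oc4ccncc4-c4cccnc4)c(F)c3)ncn2)cc1` gives 710 nM. Among the compounds with values here, the one change between them, hydrogen in place of fluoro on an aromatic carbon, produced an 11-fold lower number from compound 1 to compound 2 (1.03 log units; beyond the scatter). Compound 3 `O=C(Nc1ccc(Oc2ccncc2-c2cccnc2)c(F)c1)c1ccnn(-c2ccc(Cl)cc2)c1=O`, which carries a different amide-linked core, gives 6560 nM; its number sits close to that of compound 1, inside the scatter, while compound 2's number is clearly lower than both.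

Compound 4 `O=C(Nc1ccc(Oc2ccncc2-c2cccnc2)c(F)c1)c1ccnn(-c2ccc(F)cc2)c1=O` differs from compound 3 in a single place: fluoro in place of chloro on an aromatic carbon. Within the data shown here, no measured step matches this exchange of one halogen for another on the same aromatic carbon. Among the measured compounds shown here, the only measured step, from compound 1 to compound 2, concerns the loss of a fluoro on a different ring and on a different core, so it bears on the present change only loosely. For the measured compounds named here, with no closer precedent, a move within the scatter is the most that can be expected, and the step from compound 3 to compound 4 is estimated at a 1.2-fold lower number from compound 3 to compound 4 (0.08 log units; within the scatter). Compound 4 is therefore expected to give about 5500 nM in this assay , with a range from 2500 nM to 12000 nM.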

Compound 4, half-maximal inhibitory concentration: 2880 nM
For compound 4 the middle estimate is 1.9-fold (0.28 log units) above the measured one, within the range that was stated.
By their numbers in this assay, from the lowest: compound 2; then compound 4; then compounds 3 and 1 (each within the scatter of the next).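

In this assay, replacing 4-chlorophenyl with 4-fluorophenyl gives a 2.3-fold lower number from compound 3 to compound 4 (0.36 log units; beyond the scatter), so the halogen on this aromatic carbon, para to a large group, has a modest but readable effect on the amide-linked core. Within the data shown here, this is the first exchange of one halogen for another, and it shows that this position responds to the identity of the halogen, which the earlier compounds could not reveal. Here fluoro entering goes with the lower number, while in the earlier step, an 11-fold lower number from compound 1 to compound 2 (1.03 log units; beyond the scatter), the lower number came with fluoro leaving, on another ring of a different core; no general rule for fluoro follows from these two steps, and no measurement offered here explains either of them.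

The compounds shown leave open whether hydrogen, methyl, methoxy or a nitrile at this same carbon would give a lower or a higher number than fluoro. They also leave open whether the exchange of chloro for fluoro would have a similar effect on the core of compound 1.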